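This account rests on a few compounds, and the source may have more. Where it says the series, first, only, none or still open, it means among the compounds named here.

Compound 1 `CCN(CC)c1ccc(N2C(=O)NC3(CSC4=C3C(=O)c3ncccc3C4=O)C2=O)cc1`: 20 nM
Compound 2 `COc1ccc(N2C(=O)NC3(CSC4=C3C(=O)c3ncccc3C4=O)C2=O)cc1`: 50 nM

Both numbers come from a functional assay on ACHN cells (Homo sapiens) for antiproliferative activity, read by MTT assay, with a stated time of 96 h; a higher number here means a weaker inhibitor, a lower number a stronger inhibitor. Compound 1 holds the lowest of the two numbers; its nearest neighbour is compound 2, reached by the step of a 2.5-fold higher number from compound 1 to compound 2 (0.40 log units; beyond the scatter), which exchanges one group on an aromatic carbon of the shared core.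

Compound 3 `CC(C)(C)c1ccc(N2C(=O)NC3(CSC4=C3C(=O)c3ncccc3C4=O)C2=O)cc1` is not yet measured. It differs from compound 1 by tert-butyl in place of diethylamino on an aromatic carbon. Going by the values given here, the only measured step that bears on this change is a 2.5-fold higher number from compound 1 to compound 2 (0.40 log units; beyond the scatter), a modest loss on the same aromatic carbon of the same core, showing that removing the diethylamino group from compound 1 costs something but not a great deal. Among the compounds with values here, no measured step covers tert-butyl in place of diethylamino, so the expectation for compound 3 is a similarly modest rise in the number from this assay, a 2.0-fold higher number from compound 1 to compound 3 (0.30 log units; within the scatter). Compound 3 is estimated at 40 nM, with a range of 15 nM to 120 nM.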

Compound 3, half-maximal inhibitory concentration: 150 nM
Compound 3: middle estimate off by 3.8-fold (0.57 log units), on the low side, outside the stated range (above it).
By their numbers in this assay, from the lowest: compound 1; then compound 2; then compound 3.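

In this assay the tert-butyl exchange gives a 7.5-fold higher number from compound 1 to compound 3 (0.88 log units; beyond the scatter), a larger loss than the methoxy exchange on the same aromatic carbon, so the cost of removing diethylamino depends on the group that enters. Tert-butyl also falls behind methoxy, with a 3.0-fold higher number from compound 2 to compound 3 (0.48 log units; beyond the scatter), which places the three groups in the order diethylamino, methoxy, tert-butyl, each step beyond the scatter. Nothing in hand accounts for this order.

The compounds shown leave open whether another amine on this carbon, such as dimethylamino or morpholine, would match or improve on diethylamino, and whether the low number requires a nitrogen there at all. A hydroxyl, a carboxylic acid or a longer alkoxy chain at the same place would also test how far the order extends beyond these three groups.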